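Adding Chlorine to a Growth Hormone Secretagogue Receptor Agonist

This account rests on a few compounds, and the source may have more. Where it says the series, first, only, none or still open, it means among the compounds named here.

Measured compounds:
Compound 1 `C[C@@H]1CN(c2cccc(NS(=O)(=O)c3ccc(-c4ccccn4)s3)c2)C[C@H](C)N1` gives 0.8
Compound 2 `C[C@@H]1CN(c2ccc(Cl)c(NS(=O)(=O)c3ccc(-c4ccccn4)s3)c2)C[C@H](C)N1` gives 1
Compound 3 `COc1ccc(N2C[C@@H](C)N[C@@H](C)C2)cc1NS(=O)(=O)c1ccc(-c2cccs2)cc1` gives 1

All three were tested in a functional assay for agonist activity at growth hormone secretagogue receptor type 1 (Homo sapiens), read by FLIPR; on this read-out lower numbers stand for smaller maximal responses and higher numbers for larger maximal responses. Compound 1 and compound 2 share a core and differ by chloro in place of hydrogen on an aromatic carbon. That change gave a number 0.20 higher from compound 1 to compound 2 (beyond the scatter). Compound 3 has another core; the difference between the cores of compound 1 and compound 3 is not broken down here. Compound 3 and compound 2 stand level within the scatter, and compound 3 lies a step beyond the scatter above compound 1.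

Compound 4 `COc1ccc(N2C[C@@H](C)N[C@@H](C)C2)cc1NS(=O)(=O)c1ccc(-c2cccs2)cc1Cl` has not yet been measured. It is made from compound 3 by chloro in place of hydrogen on an aromatic carbon. This is the same kind of change as from compound 1 to compound 2, but not the same: in compound 2 the chloro sits para to a 3,5-dimethylpiperazin-1-yl group, in compound 4 it sits meta to a thiophen-2-yl group. Because compound 3 already reaches 1, little room for a rise remains, so the expected step is no change at the digits printed from compound 3 to compound 4 (within the scatter). Compound 4 is estimated at 1, expected between 0.85 and 1.1.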

Compound 4, intrinsic activity: the largest response reached, as a fraction of the reference agonist's: 0.9
Compound 4: middle estimate off by 0.10, on the high side; the range from low to high includes it.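

In this assay, putting chloro in place of hydrogen on an aromatic carbon of compound 3 gave a number 0.10 lower from compound 3 to compound 4 (within the scatter), so this change produced no step beyond the scatter on this core. Set beside the earlier step, the same change did not carry over unaltered from one core to the other: the same change on two cores in this assay, a number 0.20 higher (beyond the scatter) from compound 1 to compound 2 and a number 0.10 lower (within the scatter) from compound 3 to compound 4, 0.30 apart, beyond the scatter of two such steps. This does not show why the two steps part, as the cores differ and the chloro also sits in its own place in compound 4, ortho to a large group and meta to a thiophen-2-yl group, and two pairs of compounds cannot separate those differences.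

The compounds shown leave open whether chloro would behave alike if it stood at a matching place on both cores. They also leave open whether another group at these carbons, such as fluoro, methyl or an amine, would shift the maximal response on either core.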